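Compound 2 to compound 4: acetoxy for (phenylsulfonyl)amino

A few compounds are considered here, and "the series" means these few. Any claim that something is new, unique, unknown or untested is made for them only; others in the source may bear on it.

Measured so far in an ADME assay on cells (Hepatocyte, Homo sapiens) for metabolic stability, with a stated time of 30 min; on this read-out higher numbers stand for a more stable compound and lower numbers for a less stable compound:
- compound 1 `CS(=O)(=O)NC1CCC(CN2CCN(c3cc(=O)c4cc(C(F)(F)F)cc([N+](=O)[O-])c4s3)CC2)CC1`: 105%
- compound 2 `O=c1cc(N2CCN(CC3CCC(NS(=O)(=O)c4ccccc4)CC3)CC2)sc2c([N+](=O)[O-])cc(C(F)(F)F)cc12`: 90.8%
- compound 3 `O=c1cc(N2CCN(CC3CCCCC3)CC2)sc2c(NO)cc(C(F)(F)F)cc12`: 19.1%

Compound 2 is second highest of the three, below compound 1 and far above compound 3. The next structure is compound 4 `CC(=O)OC1CCC(CN2CCN(c3cc(=O)c4cc(C(F)(F)F)cc([N+](=O)[O-])c4s3)CC2)CC1`, which carries acetoxy in place of (phenylsulfonyl)amino on a saturated ring carbon, three ring bonds from the ring atom that bears a large group: acetoxy in place of (phenylsulfonyl)amino on a saturated ring carbon.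

Among the measured compounds shown here, one measured step bears on this change, a number 14.2 percentage points lower from compound 1 to compound 2 (beyond the scatter), with phenyl in place of methyl on a sulfonyl sulfur. It is modest and beyond the scatter, but it only exchanges one group on the sulfonyl sulfur, whereas compound 4 replaces the whole group, so it is a loose guide. Compound 3, at 19.1%, lacks the sulfonyl group too, but it also differs from compound 2 in the core, so its value cannot be assigned to one change. A modest fall in this assay is therefore expected, with wide uncertainty. The expected step is a number 18.8 percentage points lower from compound 2 to compound 4 (beyond the scatter). For compound 4 the estimated value is 72%, with an expected range of 40% to 100%.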

Compound 4, percent of the compound remaining: 0%
Estimate against measurement, compound 4: 72 percentage points above; measured number outside the range, below it.
By their numbers in this assay, from the lowest: compound 4; then compound 3; then compound 2; then compound 1.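

In this assay, the substituent on this saturated ring carbon turns out to decide the read-out, not merely adjust it: exchanging the group on the sulfonyl sulfur gave only a number 14.2 percentage points lower from compound 1 to compound 2 (beyond the scatter), whereas replacing the whole sulfonamide with acetoxy gives a number 90.8 percentage points lower from compound 2 to compound 4 (beyond the scatter) and, against the methanesulfonamido analogue, a number 105 percentage points lower from compound 1 to compound 4 (beyond the scatter). Both sulfonamides therefore sit high in this assay, and the earlier step gave no sign that the read-out at this position could fall so far with a single change, since it touched only the far end of the group. No measurement at hand bears on why acetoxy behaves so differently from either sulfonamide.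

Still open, going by these compounds, is whether this collapse belongs to acetoxy itself or would follow any loss of the sulfonamide at this ring carbon. A free hydroxyl, an acetamido group or a primary amine in the same place, each on the same core, would separate these two readings and show how much of the sulfonamide is needed to keep the compound high in this assay.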